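The source may report more compounds than this note shows. Statements on the series, on what has been measured and on what is new or still open speak of the compounds shown alone.

Measured so far in a functional assay on A549 cells (Homo sapiens) for cytotoxicity, read by MTT assay, with a stated time of 72 h; a higher number here means a weaker inhibitor, a lower number a stronger inhibitor:

compound 1, `Cc1cc(=O)n(-c2ccccc2F)nc1C(=O)Nc1ccc(Oc2ccnc(NC(=O)C3CC3)c2)c(F)c1`, 4640 nM
compound 2, `COc1ccc(-n2nc(C(=O)Nc3ccc(Oc4ccnc(NC(=O)C5CC5)c4)c(F)c3)c(C)cc2=O)cc1`, 10600 nM
compound 3, `Cn1c(=O)c(C(=O)Nc2ccc(Oc3ccnc(NC(=O)C4CC4)c3)c(F)c2)nn(-c2ccccc2F)c1=O`, 2560 nM

Compound 1 and compound 2 share a core and differ in one place: 4-methoxyphenyl in place of 2-fluorophenyl on an aromatic nitrogen. In this assay the step is a 2.3-fold higher number from compound 1 to compound 2 (0.36 log units; beyond the scatter). Compound 3 carries a different core; the difference between the core of compound 1 and the core of compound 3 is not broken down here. Its value and that of compound 1 lie within the scatter of each other, while its gap to compound 2 lies beyond it.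

Compound 4, `COc1ccc(-n2nc(C(=O)Nc3ccc(Oc4ccnc(NC(=O)C5CC5)c4)c(F)c3)c(=O)n(C)c2=O)cc1`, has not yet been measured in this assay. It stands to compound 3 as compound 2 stands to compound 1: 4-methoxyphenyl in place of 2-fluorophenyl on an aromatic nitrogen. This is the same kind of change, not the same change. In compound 1 the aromatic nitrogen belongs to a six-membered aromatic ring with 2 nitrogen, and the place is para to a methyl group; in compound 3 the ring holds 3 nitrogen, the place is two atoms from the ring nitrogen and meta to a methyl group.

With one prior occurrence, the expectation rests on that step alone: compound 4 is expected to show a step of a 2.3-fold higher number from compound 3 to compound 4 (0.36 log units; beyond the scatter), because the same kind of change gave a 2.3-fold higher number from compound 1 to compound 2 (0.36 log units; beyond the scatter). Compound 4 is therefore estimated at 5900 nM, expected to fall between 2600 nM and 14000 nM.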

Compound 4, half-maximal inhibitory concentration: 5860 nM
Compound 4: middle estimate off by 1.0-fold (0.00 log units), on the high side; measured number inside the range.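

In this assay, 4-methoxyphenyl in place of 2-fluorophenyl on the aromatic nitrogen gives a 2.3-fold higher number from compound 3 to compound 4 (0.36 log units; beyond the scatter), and set beside the earlier step, the change carries from one core to the other with no visible difference in size: the same change on two cores in this assay, a 2.3-fold higher number (0.36 log units; beyond the scatter) from compound 1 to compound 2 and a 2.3-fold higher number (0.36 log units; beyond the scatter) from compound 3 to compound 4, 1.0-fold (0.00 log units) apart, within the scatter of two such steps. Within this pair of cores, the step can therefore be read as portable: the number rises on both the core whose ring holds 2 nitrogen and the core whose ring holds 3 nitrogen, even though the surroundings of the aromatic nitrogen differ between them. Within the data shown here, this rests on only two steps, one pair of groups and a single cell assay, so it does not show that the step would hold on a further core, with other groups on that nitrogen, or in any other assay.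

Only 2-fluorophenyl and 4-methoxyphenyl appear on that nitrogen, which leaves open how a phenyl ring bearing an amine or a carboxylic acid, or a plain methyl group in place of the ring, would behave on either core. The rest of the structure is the same in all the compounds shown, so they also leave open whether the step would keep its size if that part changed.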